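Amide nitrogen substituent swap: cytotoxicity notes

A few compounds are considered here, and "the series" means these few. Any claim that something is new, unique, unknown or untested is made for them only; others in the source may bear on it.

Compound 1 `COc1ccc2c(=O)c(/C=C/C(=O)Nc3cc(C)ccc3C)coc2c1` carries a 2,5-dimethylphenyl on its amide-type nitrogen. For the measured compounds named here, in an ADME assay on HepG2 2.2.15 cells (Homo sapiens) for cytotoxicity, read by MTT assay, with stated times of 48 h and 9 days (a higher number here means that more compound is tolerated, a lower number that less compound is tolerated), compound 1 gives 1100000 nM, the highest of the two numbers measured so far. Going by the values given here, the only other measured member, compound 2 `O=C(/C=C/c1coc2cc(O)ccc2c1=O)NCc1ccc(F)cc1`, gives 357000 nM in this assay, a gap that lies beyond the scatter, so compound 1 is the better tolerated of the two.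

Compound 3 `COc1ccc2c(=O)c(/C=C/C(=O)Nc3ccc(F)cc3)coc2c1` is the next member to be tested in this assay. Relative to compound 1 the change is 4-fluorophenyl in place of 2,5-dimethylphenyl on an amide-type nitrogen. Among the compounds with values here, no step between measured compounds covers this kind of change, so the expectation rests on the shared core with compound 1 and on the value of compound 1 1100000 nM as the anchor. A small move toward less tolerance is expected, the step of a 1.6-fold lower number from compound 1 to compound 3 (0.20 log units; within the scatter) likely staying within or close to the scatter. Compound 3 is estimated at 700000 nM, with a range from 250000 nM to 1500000 nM in this assay.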

Compound 3, half-maximal cytotoxic concentration: 743000 nM
Compound 3: the middle estimate sits 1.1-fold (0.03 log units) below what was measured; the range from low to high includes it.
By their numbers in this assay, from the lowest: compound 2; then compounds 3 and 1 (each within the scatter of the next).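

Notes on the step: on the amide-type nitrogen of the shared core, 4-fluorophenyl in place of 2,5-dimethylphenyl gives, in this assay, a difference that does not separate the two compounds (a 1.5-fold lower number from compound 1 to compound 3 (0.17 log units; within the scatter)). For the compounds shown here, this is the first step between compounds that differ in one place, and it shows that this nitrogen can carry either of these two substituted phenyl groups with no difference beyond the scatter. No measurement shown here offers an explanation for this result.

A single step cannot separate the loss of the two methyl groups from the gain of the fluorine. Also open, on these data alone, is whether the same holds for an unsubstituted phenyl, a cyclohexyl or a phenyl bearing a carboxylic acid on this nitrogen.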